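Adding an iodo group to compound 3

The source may report more compounds than this note shows. Statements on the series, on what has been measured and on what is new or still open speak of the compounds shown alone.

Compound 1 `NC(=O)c1c(NC(=O)c2ccccc2Cl)sc2c1CCN(Cc1ccc(Cl)cc1)C2`, compound 2 `NC(=O)c1c(NC(=O)c2ccccc2Cl)sc2c1CCN(C(=S)Nc1ccccc1F)C2` and compound 3 `NC(=O)c1c(NC(=O)c2ccccc2)sc2c1CCN(C(=S)Nc1ccccc1Cl)C2` share one core and were tested in a functional assay on HeLa cells (Homo sapiens) for antiproliferative activity, with a stated time of 24 h; on this read-out higher numbers stand for weaker inhibition and lower numbers for stronger inhibition. In this assay compound 1 gives only a limit, > 50000 nM. In this assay compound 2 gives 28700 nM. In this assay compound 3 likewise gives only a limit, > 50000 nM. Going by the values given here, the single step between compounds differing in one place is an at least 1.7-fold lower number from compound 1 to compound 2 (0.24 log units; that floor lies within the scatter), and since (the limit of > 50000 nM in this assay, at which 2 of the 3 values shown sit), that step cannot be sized more closely. Among the compounds with values here, compound 2 and compound 3 differ in two places, so their values show only that one gives a number and the other a limit. Compound 4 `NC(=O)c1c(NC(=O)c2ccccc2I)sc2c1CCN(C(=S)Nc1ccccc1Cl)C2` differs from compound 3 by iodo in place of hydrogen on an aromatic carbon. Within the data shown here, no measured step touches that position, and the step from compound 1 to compound 2 concerns the amine nitrogen instead, so no direction is supported beyond the scatter. Compound 4 is therefore expected to give about 45000 nM in this assay, between 15000 nM and 120000 nM. That estimate means an at least 1.1-fold lower number from compound 3 to compound 4 (0.04 log units; that floor lies within the scatter), expected to stay within the scatter.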

Compound 4, half-maximal inhibitory concentration: > 50000 nM
Compound 4: only a limit was reported; the forecaster's own chance of this, stated with the estimate: 50%; middle value at least 1.1-fold (0.04 log units) from the limit.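

Going by these compounds alone, compound 3 and compound 4 each give only a limit in this assay, so no step between them can be read: the limit of > 50000 nM in this assay, at which 3 of the 4 values shown sit. The compounds shown leave open whether iodo in place of hydrogen on an aromatic carbon shifts the number in this assay at all.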